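A few compounds are considered here, and "the series" means these few. Any claim that something is new, unique, unknown or untested is made for them only; others in the source may bear on it.

In a functional assay on HeLa cells (Homo sapiens) for antiproliferative activity, read by sulforhodamine B assay, with a stated time of 48 h (a higher number here means a weaker inhibitor, a lower number a stronger inhibitor), two compounds with closely related cores have been measured so far. Compound 1 `COc1cc(OC)c2sc(-c3ccc(N/C=C\C(=O)c4ccc(OC)c([N+](=O)[O-])c4)cc3)nc2c1` gives 12900 nM, and compound 2 `COc1ccc(C(=O)/C=C\Nc2ccc(-c3nc4cc(OC)c(OC)c(OC)c4s3)cc2)cc1[N+](=O)[O-]` gives 11400 nM. These two numbers lie within the usual scatter of repeated measurements, so compound 2 cannot be ranked apart from compound 1.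

The next structure, compound 3 `COc1cc(C(=O)/C=C\Nc2ccc(-c3nc4cc(OC)c(OC)c(OC)c4s3)cc2)cc(OC)c1OC`, keeps the core of compound 2 and changes one group: 3,4,5-trimethoxyphenyl in place of 4-methoxy-3-nitrophenyl on a carbonyl carbon. Put simply, 3,4,5-trimethoxyphenyl takes the place of 4-methoxy-3-nitrophenyl on a carbonyl carbon.

For the measured compounds named here, only one measured step exists, a 1.1-fold lower number from compound 1 to compound 2 (0.05 log units; within the scatter). It comes from a different change, methoxy in place of hydrogen on an aromatic carbon, so it offers only weak guidance here. Going by the values given here, no measured pair varies the group on the carbonyl, and the data therefore give no direction for this swap. In this assay, no step beyond the scatter is expected, although the uncertainty is wide. The expected move is a 1.4-fold lower number from compound 2 to compound 3 (0.15 log units; within the scatter). For compound 3 the estimated value is 8000 nM, with an expected range from 2000 nM to 30000 nM.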

Compound 3, half-maximal inhibitory concentration: 5300 nM
The estimate for compound 3 lay 1.5-fold (0.18 log units) above the measured number, within the range that was stated.
By their numbers in this assay, from the lowest: compound 3; then compounds 2 and 1 (each within the scatter of the next).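

In this assay, the group on the carbonyl carbon proves to matter: 3,4,5-trimethoxyphenyl in place of 4-methoxy-3-nitrophenyl gives a 2.2-fold lower number from compound 2 to compound 3 (0.33 log units; beyond the scatter), a modest step, but the only one among these compounds that lies beyond the scatter. For the compounds shown here, the earlier pair differed by a single methoxy on an aromatic carbon and could not be told apart, so this is the first sign that the number responds to a change in structure, and it does so at a place the earlier compounds left untouched. The two groups both hold one six-membered aromatic ring of carbon only and match in hydrogen-bond donors and acceptors, but nothing measured here explains why the swap lowers the number.

Because the swap removes the nitro group and brings in methoxy groups in one move, this single pair cannot show which of the two alterations drives the step, or whether the same swap would hold on the core of compound 1. Other groups on the carbonyl carbon, such as an unsubstituted phenyl or a phenyl carrying an amine or a carboxylic acid, would show how far the number can move at this place.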